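The source may report more compounds than this note shows. Statements on the series, on what has been measured and on what is new or still open speak of the compounds shown alone.

In a functional assay for antagonist activity at thromboxane A2 receptor (Rattus norvegicus) (on this read-out higher numbers stand for weaker binding and lower numbers for tighter binding), the measured compounds are:
compound 1, `CC(=O)NCc1ccccc1-c1ccc(COC2CC[C@H](N3CCCCCC3)[C@H]2OC/C=C\CCC(=O)O)cc1`, 126 nM
compound 2, `NC(=O)Cc1ccccc1-c1ccc(COC2CC[C@H](N3CCCCCC3)[C@H]2OC/C=C\CCC(=O)O)cc1`, 158 nM
compound 3, `CC(=O)NCc1ccc(-c2ccc(COC3CC[C@H](N4CCCCCC4)[C@H]3OC/C=C\CCC(=O)O)cc2)cc1`, 20 nM

Compound 3 has the lowest number of the three in this assay, and its steps to the other two are both beyond the scatter, namely a 6.3-fold lower number from compound 1 to compound 3 (0.80 log units; beyond the scatter) and a 7.9-fold lower number from compound 2 to compound 3 (0.90 log units; beyond the scatter). Compound 1 and compound 2 differ only in the group on the saturated chain carbon, and a 1.3-fold higher number from compound 1 to compound 2 (0.10 log units; within the scatter) lies within the scatter.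

Compound 4, `O=C(O)CC/C=C\CO[C@H]1C(OCc2ccc(-c3ccccc3O)cc2)CC[C@@H]1N1CCCCCC1`, has not yet been measured in this assay. It differs from compound 3 in one place: 2-hydroxyphenyl in place of 4-(acetamidomethyl)phenyl on an aromatic carbon. Within the data shown here, two measured steps bear on this change. The step of a 6.3-fold lower number from compound 1 to compound 3 (0.80 log units; beyond the scatter) replaced 2-(acetamidomethyl)phenyl with 4-(acetamidomethyl)phenyl and brought the number down; the change to compound 4 goes the other way, back to a ring substituted in the 2-position, while the acetamidomethyl group disappears altogether. The step of a 1.3-fold higher number from compound 1 to compound 2 (0.10 log units; within the scatter) shows that exchanging the group on that chain carbon changes little. Among the measured compounds shown here, no measured pair tests a hydroxyphenyl or the loss of the chain carbon, so the estimate leans on the position change. A higher number is therefore expected for compound 4 in this assay, with a 5.0-fold higher number from compound 3 to compound 4 (0.70 log units; beyond the scatter). Compound 4 is estimated at 100 nM, in the range 30 nM to 400 nM.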

Compound 4, dissociation constant: 20 nM
The estimate for compound 4 lay 5.0-fold (0.70 log units) above the measured number; measured number below the stated range.
By their numbers in this assay, from the lowest: compounds 3 and 4 (each within the scatter of the next); then compounds 1 and 2 (each within the scatter of the next).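

In this assay, the aromatic carbon para to a large group takes 2-hydroxyphenyl as readily as 4-(acetamidomethyl)phenyl, with no change at the digits printed from compound 3 to compound 4 (within the scatter), even though the entering group has fewer heavy atoms and no double bond outside aromatic rings. The 2-hydroxyphenyl group also does not share the higher numbers of the groups it replaces in compound 1 and compound 2: hydroxy in place of acetamidomethyl gives a 6.3-fold lower number from compound 1 to compound 4 (0.80 log units; beyond the scatter), and hydroxy in place of carbamoylmethyl gives a 7.9-fold lower number from compound 2 to compound 4 (0.90 log units; beyond the scatter), so among these four compounds the number follows the identity of the substituent, and not its place on the ring alone. Nothing available here bears on why these two groups read alike.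

What the compounds shown leave open is whether the hydroxy group itself carries this result, a question that a methoxy group, an amino group or a bare phenyl ring at this position would address. They also leave open whether 4-hydroxyphenyl would match 2-hydroxyphenyl, or would differ from it as the two acetamidomethyl rings differ.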